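The source may report more compounds than this note shows. Statements on the series, on what has been measured and on what is new or still open speak of the compounds shown alone.

Working notes on the series. In a functional assay on a cell-free system (plasma) with thromboxane A2 receptor (Homo sapiens) as the target (on this read-out lower numbers stand for stronger inhibition and higher numbers for weaker inhibition), compound 1 `O=C(O)CCC/C=C\CC1C2CCC(O2)C1CSCCOc1ccccc1` gives 20000 nM and compound 2 `CCCCCC(C)SCC1C2CCC(O2)C1C/C=C\CCCC(=O)O` gives 3800 nM. The step of a 5.3-fold lower number from compound 1 to compound 2 (0.72 log units; beyond the scatter) is the only measured one, and compound 2 holds the lower of the two numbers. Compound 3 `CCCNC(=O)CSCC1C2CCC(O2)C1C/C=C\CCCC(=O)O` differs from compound 2 by (propylcarbamoyl)methyl in place of 1-methylhexyl on a sulfur, the same sulfur at which the measured step was taken. For the measured compounds named here, that step bears on it only as a precedent for swaps at this sulfur; the entering group has no measured counterpart, so the direction is uncertain. A step of the order of a 2.1-fold higher number from compound 2 to compound 3 (0.32 log units; beyond the scatter) toward a higher number is expected. Compound 3 is therefore estimated at 8000 nM in this assay, between 2000 nM and 30000 nM.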

Compound 3, half-maximal inhibitory concentration: 72000 nM
Compound 3: middle estimate off by 9.0-fold (0.95 log units), on the low side; the whole stated range lies below it.
By their numbers in this assay, from the lowest: compound 2; then compound 1; then compound 3.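

At this sulfur, in this assay, the choice of group can produce a large step, not only the modest one seen earlier: a 19-fold higher number from compound 2 to compound 3 (1.28 log units; beyond the scatter). The (propylcarbamoyl)methyl group also gives a higher number than the 2-phenoxyethyl group, with a 3.6-fold higher number from compound 1 to compound 3 (0.56 log units; beyond the scatter). Both 1-methylhexyl and (propylcarbamoyl)methyl hold 7 heavy atoms, so the large step comes without a change in that count, and no supporting measurement accounts for it.

Still open, going by these compounds, is whether the amide itself or the propyl end tracks with the higher number. An ester in place of the amide, or a longer chain on its nitrogen, would test this.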